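The source may hold more compounds than are shown below. What is called first, only, known or untested is meant among the compounds shown, and "the series" means these compounds.

The measured compounds, all read in a functional assay on MKN-45 cells (Homo sapiens) for cytotoxicity, read by MTT assay, with a stated time of 72 h; on this read-out lower numbers stand for stronger inhibition and higher numbers for weaker inhibition:

Compound 1 `COc1cc2c(Oc3ccc(NC(=O)c4cc(-c5ccccc5)ccn4)cc3F)ccnc2cc1OCCCN1CCN(C)CC1` gives 150 nM.
Compound 2 `COc1cc2c(Oc3ccc(NC(=O)c4cc(-c5ccccc5F)ccn4)cc3F)ccnc2cc1OCCCN1CCCCC1` gives 180 nM.
Compound 3 `COc1cc2c(Oc3ccc(NC(=O)c4cc(-c5ccc(C(F)(F)F)cc5)ccn4)cc3F)ccnc2cc1OCCCN1CCCCC1` gives 870 nM.

Compound 1 has the lowest of the three numbers; compound 2 lies within the scatter of it, while compound 3 lies beyond it. Compound 4 `COc1cc2c(Oc3ccc(NC(=O)c4cc(-c5ccccc5C)ccn4)cc3F)ccnc2cc1OCCCN1CCN(C)CC1` is compound 1 with methyl in place of hydrogen on an aromatic carbon. Among the measured compounds shown here, no measured step repeats this change. For the measured compounds named here, the one step on the same ring, a 4.8-fold higher number from compound 2 to compound 3 (0.68 log units; beyond the scatter), is a different group in a different place, so it is only a loose guide. Going by the values given here, compound 1 and compound 2, which differ by a fluorine on that ring, sit within the scatter of each other, which points to a small or no step. For compound 4, a 1.3-fold higher number from compound 1 to compound 4 (0.10 log units; within the scatter) is expected, so an estimate of 190 nM, between 70 nM and 500 nM.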

Compound 4, half-maximal inhibitory concentration: 240 nM
The estimate for compound 4 lay 1.3-fold (0.10 log units) below the measured number, and the stated range covers the measured number.
By their numbers in this assay, from the lowest: compounds 1, 2 and 4 (each within the scatter of the next); then compound 3.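

In this assay, methyl in place of hydrogen on an aromatic carbon, ortho to a large group, gives a 1.6-fold higher number from compound 1 to compound 4 (0.20 log units; within the scatter). Among the compounds shown here, this is the first reading of a single added group at this place, and it shows that phenyl to 2-methylphenyl leaves the number within the scatter, whereas the earlier step on this ring changed both the group and its place. No measurement shown here accounts for this result. On these data alone, whether a longer chain, an amine or a carboxylic acid at this place would also stay within the scatter remains open.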